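Swapping a methyl ester for an aziridine amide

This account rests on a few compounds, and the source may have more. Where it says the series, first, only, none or still open, it means among the compounds named here.

Compound 1 `COC(=O)c1cc(N)c(Nc2ccc(C#N)cc2)cc1Oc1c(C)cc(/C=C/C#N)cc1C` is measured in an ADME assay on microsomes from liver (Homo sapiens) for metabolic stability, read by LC-MS, using NADPH, with a stated time of 45 min, tested at 1 uM (a higher number here means that the compound lasts longer, a lower number that the compound disappears faster), and gives 0.308 h. Among the three compounds with numbers, compound 1 stands second highest: its closest neighbour is compound 2 `Cc1cc(/C=C/C#N)cc(C)c1Oc1cc(Nc2ccc(C#N)cc2)c(N)cc1C(=O)OCCC#N` with 0.283 h, and the step of a 1.1-fold lower number from compound 1 to compound 2 (0.04 log units; within the scatter) lies within the scatter. For the measured compounds named here, compound 3 `CCNC(=O)c1cc(N)c(Nc2ccc(C#N)cc2)cc1Oc1c(C)cc(/C=C/C#N)cc1C` is the furthest away with 2.32 h, and the step of a 7.5-fold higher number from compound 1 to compound 3 (0.88 log units; beyond the scatter) is the only change here that moves the number beyond the scatter. The step of an 8.2-fold higher number from compound 2 to compound 3 (0.91 log units; beyond the scatter) points the same way.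

Compound 4 `Cc1cc(/C=C/C#N)cc(C)c1Oc1cc(Nc2ccc(C#N)cc2)c(N)cc1C(=O)N1CC1` has not yet been measured. It differs from compound 1 in one place: aziridin-1-yl in place of methoxy on a carbonyl carbon. Going by the values given here, both this change and the one from compound 1 to compound 3 remove the methoxy from the carbonyl carbon and put a nitrogen-bound group there. The step of a 7.5-fold higher number from compound 1 to compound 3 (0.88 log units; beyond the scatter) is the one that bears most on it. The step of a 1.1-fold lower number from compound 1 to compound 2 (0.04 log units; within the scatter), which only lengthens the chain on the oxygen side, says little. Aziridin-1-yl is not ethylamino, so the full size of that step is not guaranteed. For compound 4 an upward step of a 3.2-fold higher number from compound 1 to compound 4 (0.51 log units; beyond the scatter) is expected in this assay, giving an estimated 1 h, with a range from 0.4 h to 2.5 h.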

Compound 4, half-life: 2.63 h
The estimate for compound 4 lay 2.6-fold (0.42 log units) below the measured number; measured number outside the range, above it.
By their numbers in this assay, from the lowest: compounds 2 and 1 (each within the scatter of the next); then compounds 3 and 4 (each within the scatter of the next).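

In this assay, the aziridin-1-yl amide stands clearly above both esters, with an 8.5-fold higher number from compound 1 to compound 4 (0.93 log units; beyond the scatter) and a 9.3-fold higher number from compound 2 to compound 4 (0.97 log units; beyond the scatter) as the steps, so the rise seen earlier with ethylamino on this carbonyl carbon is not confined to that one group. The two amides cannot be told apart, since a 1.1-fold higher number from compound 3 to compound 4 (0.05 log units; within the scatter) is the step between them; across these four compounds, a nitrogen-bound group on the carbonyl carbon gives the higher numbers, and the amide hydrogen of compound 3, absent from compound 4, is not required for them. Nothing shown gives a measured reason for the rise or says what happens to any of these compounds in the microsomes.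

Still open, on these data alone, is how far this reaches among other nitrogen-bound groups, such as a pyrrolidine or piperidine amide with a larger ring, a dimethylamino amide, or the plain unsubstituted amide. A carboxylic acid on the same carbonyl carbon is also an open case, and these four compounds cannot say where it would fall relative to the esters and the amides.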